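Swapping the aryl end of the chain: from chlorine to isopropyl

A few compounds are considered here, and "the series" means these few. Any claim that something is new, unique, unknown or untested is made for them only; others in the source may bear on it.

Measured so far:
compound 1, `Cc1ccc(/C=C/C(=O)c2cccc(NC(=O)c3cc(-c4ccncc4)n[nH]3)c2)cc1`, gives 69400 nM
compound 2, `O=C(/C=C/c1ccccc1Cl)c1cccc(NC(=O)c2cc(-c3ccncc3)n[nH]2)c1`, gives 27700 nM

Both compounds were tested in a functional assay, read by spectrophotometry, tested at 100 uM; a higher number here means a weaker inhibitor, a lower number a stronger inhibitor. For the measured compounds named here, compound 2 has the lowest of the two numbers; its nearest neighbour is compound 1, and the single step of a 2.5-fold lower number from compound 1 to compound 2 (0.40 log units; beyond the scatter) is beyond the scatter, so compound 2 is the stronger inhibitor of the pair.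

Compound 3, `CC(C)c1ccc(/C=C/C(=O)c2cccc(NC(=O)c3cc(-c4ccncc4)n[nH]3)c2)cc1`, is not yet measured. It differs from compound 2 in one place: 4-isopropylphenyl in place of 2-chlorophenyl on a double-bonded chain carbon bound to a double-bonded chain carbon. Going by the values given here, this change removes the group that compound 2 gained over compound 1 and puts back a 4-alkylphenyl of the kind compound 1 carries, so the step of a 2.5-fold lower number from compound 1 to compound 2 (0.40 log units; beyond the scatter) is the only measured step that bears on it, and it is expected to run in reverse. Compound 3 is therefore expected to show a weaker inhibition than compound 2, about a 2.2-fold higher number from compound 2 to compound 3 (0.34 log units; beyond the scatter), landing near compound 1. The estimate for compound 3 is 60000 nM, within 25000 nM to 150000 nM.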

Compound 3, half-maximal inhibitory concentration: 52300 nM
The estimate for compound 3 lay 1.1-fold (0.06 log units) above the measured number; the range from low to high includes it.
By their numbers in this assay, from the lowest: compounds 2, 3 and 1 (each within the scatter of the next, the first and the last beyond it).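

In this assay, replacing the 2-chlorophenyl on this chain carbon with 4-isopropylphenyl gives a difference within the scatter (a 1.9-fold higher number from compound 2 to compound 3 (0.28 log units; within the scatter)), and so does replacing methyl with isopropyl on the aromatic carbon (a 1.3-fold lower number from compound 1 to compound 3 (0.12 log units; within the scatter)). Compound 3 therefore cannot be separated from either neighbour, even though compound 1 and compound 2 lie beyond the scatter of each other, so neither change has a clear effect on its own and the one readable gap in this set remains modest. Nothing measured here explains these numbers.

As far as these compounds go, it remains open whether a group of another kind on this aromatic ring, such as an amine or a carboxylic acid, would shift the number beyond the scatter. The compounds shown also cannot separate the effect of moving a substituent around the ring from the effect of changing the substituent itself.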